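The source may hold more compounds than are shown below. What is called first, only, known or untested is meant among the compounds shown, and "the series" means these compounds.

Working notes on a small amide series assessed in a functional assay on HEK293 cells for agonist activity at probable G-protein coupled receptor 27 (Homo sapiens), read by a luciferase reporter and beta-arrestin recruitment, with a stated time of 10 min; a lower number here means a smaller maximal response, a higher number a larger maximal response. Compound 1 `O=C(Nc1ccc(S(=O)(=O)Nc2ccccc2)cc1)c1cc(F)c(Cl)cc1F` gives 37% in this assay. Among the compounds with values here, compound 2 `CN(c1ccccc1)S(=O)(=O)c1ccc(NC(=O)c2ccc(Cl)cc2Cl)cc1` gives 50% in this assay, a number that sits above that of compound 1 by more than the usual scatter; the two differ in more than one place, so no single step is counted between them. Compound 3 `COc1ccc(NS(=O)(=O)c2ccc(NC(=O)c3ccc(Cl)cc3Cl)cc2)cc1` belongs to the same set, but in this assay compound 3 has "not determined" (no result reported), so no number stands for it. Of the two numbers in hand, compound 1 therefore holds the lower one.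

The next compound, compound 4 `O=C(Nc1ccc(S(=O)(=O)Nc2ccccc2)cc1)c1ccc(I)cc1F`, departs from compound 1 in one place: 2-fluoro-4-iodophenyl in place of 4-chloro-2,5-difluorophenyl on a carbonyl carbon. The amide-type nitrogen and the rest of the shared core stay as they are.

Within the data shown here, no counted step of this kind exists among the measured compounds, so the expectation rests on compound 1 alone. The exchange on the carbonyl carbon is expected to move the maximal response only a little, with no clear direction beyond the scatter. Compound 4 is therefore expected to give 40% in this assay, within 25% to 60%. The expected step is a number 3 percentage points higher from compound 1 to compound 4 (within the scatter), a change that is estimated to stay within the scatter.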

Compound 4, largest response reached (Emax), in percent of the reference or control that the assay uses: 36%
For compound 4 the middle estimate is 4 percentage points above the measured one, within the range that was stated.
By their numbers in this assay, from the lowest: compounds 4 and 1 (each within the scatter of the next); then compound 2.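

In this assay, within the data shown here, the only counted step is a number 1 percentage points lower from compound 1 to compound 4 (within the scatter), with 2-fluoro-4-iodophenyl in place of 4-chloro-2,5-difluorophenyl on a carbonyl carbon. Among these compounds, on the core of compound 1, this position therefore accepts a different halogen pattern, with iodine entering and chlorine and one fluorine leaving, without a change in maximal response that can be told from the scatter; the earlier compounds offered no single-place comparison that could show this. The data offered here give no measured explanation for this result.

All the groups shown on this carbonyl carbon are halogenated phenyl rings, so it remains open whether a different kind of group there, such as a pyridine ring, an aliphatic amine or a chain ending in a carboxylic acid, would keep the response in the same range. Among the compounds shown here, from compound 1 and compound 4, no single step leads to compound 2, so its 50% cannot be assigned to any one exchange.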